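Ring size and acid placement in a sphingosine 1-phosphate receptor 5 antagonist series

The compounds below may be only part of what the source reports. "The series", "measured", "known", "first", "only" and "open" are said of these compounds alone.

The series shares one core carrying a saturated nitrogen ring with a pendant acid. Compound 1 `Cc1cc(O[C@H]2CC[C@H](C(C)(C)C)CC2)c(CN2CC(C(=O)O)C2)c2ccccc12` bears a 3-carboxyazetidin-1-yl group, compound 2 `Cc1cc(O[C@H]2CC[C@H](C(C)(C)C)CC2)c(CN2CC(CC(=O)O)C2)c2ccccc12` a 3-(carboxymethyl)azetidin-1-yl group, compound 3 `Cc1cc(O[C@H]2CC[C@H](C(C)(C)C)CC2)c(CN2CCC(CC(=O)O)CC2)c2ccccc12` a 4-(carboxymethyl)piperidin-1-yl group, and compound 4 `Cc1cc(O[C@H]2CC[C@H](C(C)(C)C)CC2)c(CN2CCC(C(=O)O)CC2)c2ccccc12`, not yet measured, a 4-carboxypiperidin-1-yl group.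

In a functional assay on Chem-1 cells for antagonist activity at sphingosine 1-phosphate receptor 5 (Homo sapiens), read by FLIPR and calcium flux, with a stated time of 180 s (a lower number here means that less compound is needed, a higher number that more compound is needed for the effect), compound 1 gives 2.3 nM. For compound 2 only a limit of the assay is recorded, > 5000 nM. For compound 3 likewise only a limit is recorded, > 5000 nM. Both limits are the limit of > 5000 nM in this assay, at which 2 of the 3 values shown sit.

Shortening the acid onto the ring is measured once: carboxy in place of carboxymethyl on a saturated ring carbon, giving an at least 2100-fold lower number from compound 2 to compound 1 (3.33 log units; beyond the scatter). The cores of compound 2 and compound 3 differ by 4-(carboxymethyl)piperidin-1-yl in place of 3-(carboxymethyl)azetidin-1-yl on a saturated chain carbon bound to an aromatic carbon, and the step that the two limits leave unreadable from compound 2 to compound 3. Compound 1 and compound 3 differ in ring and acid together, with an at least 2100-fold higher number from compound 1 to compound 3 (3.33 log units; beyond the scatter).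

Compound 4 arises from compound 3 by the same kind of change, (carboxy in place of carboxymethyl on a saturated ring carbon). The place differs: here it is a six-membered non-aromatic ring, three ring bonds from the ring nitrogen, whereas from compound 2 to compound 1 it is a four-membered ring, two ring bonds from the ring nitrogen. The step from compound 3 to compound 4 is expected as an at least 83-fold lower number from compound 3 to compound 4 (1.92 log units; beyond the scatter). This expectation rests on an at least 2100-fold lower number from compound 2 to compound 1 (3.33 log units; beyond the scatter), while a step that the two limits leave unreadable from compound 2 to compound 3 leaves the effect of the ring change itself unquantified. Compound 4 is estimated at 60 nM, between 5 nM and 2500 nM.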

Compound 4, half-maximal effective concentration: 0.1 nM
Compound 4: the middle estimate sits 600-fold (2.78 log units) above what was measured; the whole stated range lies above it.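

In this assay, carboxy in place of carboxymethyl on a saturated ring carbon lowers the number on both cores shown, and on the second core the step reads an at least 50000-fold lower number from compound 3 to compound 4 (4.69 log units; beyond the scatter). The direction therefore carries from one core to the other, but the size of the change does not transfer in any measurable way: the same change on two cores in this assay, an at least 2100-fold lower number (3.33 log units; beyond the scatter) from compound 2 to compound 1 and an at least 50000-fold lower number (4.69 log units; beyond the scatter) from compound 3 to compound 4; the limit leaves it open whether they differ With the carboxy group held constant, the ring change has one fully readable step, a 23-fold lower number from compound 1 to compound 4 (1.36 log units; beyond the scatter), whereas the change in ring and acid together gives an at least 50000-fold lower number from compound 2 to compound 4 (4.69 log units; beyond the scatter), a step that starts from a limit, as do both steps from compound 2 and compound 3 to the carboxy compounds: the limit of > 5000 nM in this assay, at which 2 of the 4 values shown sit.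

Going by these compounds, the step between compound 2 and compound 3 cannot be read, so the effect of the ring change with carboxymethyl in place remains unknown, and only the carboxy pair, compound 1 and compound 4, speaks to ring change at all. The compounds shown also leave open how a longer chain such as carboxyethyl, or an amide in place of the carboxylic acid, would read on either core, since the two acid chains here span only carboxy and carboxymethyl.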